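Swapping Bromo for Methyl on the Aryl Ring

The source may hold more compounds than are shown below. What is called first, only, known or untested is meant among the compounds shown, and "the series" means these compounds.

Compound 1 `C/C(=N\Nc1nc(-c2ccc(Cl)cc2)cs1)c1sc(-c2ccccc2)nc1C` reaches only > 100 ug/mL in a toxicity assay on MCF7 cells (Homo sapiens) for cytotoxicity, read by MTT assay (on this read-out lower numbers stand for stronger inhibition of growth and higher numbers for weaker inhibition of growth), which is a limit of the assay and not a number. Within the data shown here, compound 2 `C/C(=N\Nc1nc(-c2ccc(Br)cc2)cs1)c1sc(-c2ccccc2)nc1C` gives 26.3 ug/mL in this assay, the only true number among the two values shown. Among the measured compounds shown here, the single measured step is an at least 3.8-fold lower number from compound 1 to compound 2 (0.58 log units; beyond the scatter), and compound 1 sits at the limit of > 100 ug/mL in this assay, at which 1 of the 2 values shown sits. Compound 3 `C/C(=N\Nc1nc(-c2ccc(C)cc2)cs1)c1sc(-c2ccccc2)nc1C` differs from compound 2 by methyl in place of bromo on an aromatic carbon. For the measured compounds named here, no measured step covers methyl replacing bromo; the one step recorded concerned a halogen swap and was at least modest in size, so a change of comparable size is expected for compound 3 in this assay, most likely toward a higher number. The expected step is a 1.7-fold higher number from compound 2 to compound 3 (0.23 log units; within the scatter). Compound 3 is therefore estimated at 45 ug/mL, with a plausible range from 15 ug/mL to 100 ug/mL.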

Compound 3, concentration for 50% growth inhibition: > 100 ug/mL
Compound 3: a limit, no number; the forecaster's own chance of this, stated with the estimate: 30%; middle value at least 2.2-fold (0.34 log units) away from the limit.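

In this assay, replacing bromo with methyl on the aromatic carbon gives an at least 3.8-fold higher number from compound 2 to compound 3 (0.58 log units; beyond the scatter), so a non-halogen group at this place also loses the stronger growth inhibition seen with compound 2. Among these three compounds, the 4-bromophenyl group of compound 2 is thus the only one that gives a true number, while the chloro and methyl groups of compound 1 and compound 3 both end at a limit of the assay and not at a number: the limit of > 100 ug/mL in this assay, at which 2 of the 3 values shown sit. The step between compound 1 and compound 3 cannot be read, as both values are limits.

As far as these compounds go, how far compound 1 and compound 3 lie from compound 2 remains open beyond what the limits show. Also open, from the compounds shown here alone, is whether iodo, methoxy or an amine at this place would give a true number like bromo.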